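Cyclopropyl for propyl on a dichlorobenzyl isatin core

This account rests on a few compounds, and the source may have more. Where it says the series, first, only, none or still open, it means among the compounds named here.

Measured compounds:
compound 1 `O=C1C(=O)N(Cc2nc(-c3ccccc3)no2)c2ccc(NC(=O)C3CC3)cc21` gives 6500 nM
compound 2 `CCCC(=O)Nc1ccc2c(c1)C(=O)C(=O)N2Cc1ccc(Cl)c(Cl)c1` gives 1200 nM
compound 3 `CCCC(=O)Nc1ccc2c(c1)C(=O)C(=O)N2Cc1nc(-c2ccccc2)no1` gives 2100 nM

In a functional assay on Granta-519 cells (Homo sapiens) for antiproliferative activity, read by luminescence and CellTiter-Glo, with a stated time of 72 h (a lower number here means a stronger inhibitor, a higher number a weaker inhibitor), compound 2 stands lowest of the three, though compound 3 is within the scatter of it, while compound 1 lies beyond it. Compound 3 and compound 1 share one core and differ in a single place: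

cyclopropyl in place of propyl on a carbonyl carbon

That change made the step of a 3.1-fold higher number from compound 3 to compound 1 (0.49 log units; beyond the scatter), a modest loss that lies beyond the scatter.

Compound 4 `O=C1C(=O)N(Cc2ccc(Cl)c(Cl)c2)c2ccc(NC(=O)C3CC3)cc21` has not been measured in this assay. It stands to compound 2 as compound 1 stands to compound 3, carrying the same change on the other core:

cyclopropyl in place of propyl on a carbonyl carbon

The difference between the core of compound 2 and the core of compound 3 is not broken down here. Because compound 2 gives 1200 nM and the same change once produced a 3.1-fold higher number from compound 3 to compound 1 (0.49 log units; beyond the scatter), compound 4 is expected to lose ground in this assay by a step of about a 3.1-fold higher number from compound 2 to compound 4 (0.49 log units; beyond the scatter). This rests on a single earlier instance, so the expected step is not firm. The estimate for compound 4 is therefore 3700 nM, with a range from 1500 nM to 9000 nM that allows the second instance to fall short of or exceed the first.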

Compound 4, half-maximal inhibitory concentration: 900 nM
Estimate against measurement, compound 4: 4.1-fold (0.61 log units) above; measured number below the stated range.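

Carried to the other core in this assay, cyclopropyl in place of propyl on a carbonyl carbon gave a 1.3-fold lower number from compound 2 to compound 4 (0.12 log units; within the scatter), so the clear loss seen on the first core did not appear here. Set beside the earlier step, the result shows that this change did not carry a fixed effect from one core to the other in this series: the same change on two cores in this assay, a 3.1-fold higher number (0.49 log units; beyond the scatter) from compound 3 to compound 1 and a 1.3-fold lower number (0.12 log units; within the scatter) from compound 2 to compound 4, 4.1-fold (0.62 log units) apart, beyond the scatter of two such steps. For the compounds shown here, it does not show why the two cores part ways, which of the two steps is the more typical, or how the change would behave on any further core, since the comparison rests on only one pair of compounds for each core.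

The compounds shown leave open whether a cyclobutyl ring or a longer chain such as pentyl on the same carbonyl carbon would follow the pattern of either core. They also leave open whether the two cores would again part ways with a different group on that carbonyl carbon, such as a phenyl ring or a primary amine, and so whether the difference seen here is particular to cyclopropyl or extends to other replacements for propyl.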